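The source may report more compounds than this note shows. Statements on the series, on what has been measured and on what is new or still open speak of the compounds shown alone.

Measured compounds:
- compound 1, `COc1cc2c(Oc3ccc(NC(=O)c4cn(-c5ccccc5)nn4)cc3F)ccnc2cc1OCCCN1CCCC1`: 260 nM
- compound 2, `COc1cc2c(Oc3ccc(NC(=O)c4cn(-c5ccccc5Cl)nn4)cc3F)ccnc2cc1OCCCN1CCCC1`: 70 nM
- compound 3, `COc1cc2c(Oc3ccc(NC(=O)c4cn(-c5ccccc5C)nn4)cc3F)ccnc2cc1OCCCN1CCCC1`: "not determined" (no result reported)

All three share one core and differ only in the group on the outer aromatic ring. In a functional assay on MKN-45 cells (Homo sapiens) for cytotoxicity, read by MTT assay, with a stated time of 72 h (on this read-out lower numbers stand for stronger inhibition and higher numbers for weaker inhibition), compound 1 gives 260 nM and compound 2 gives 70 nM. For the measured compounds named here, the one step measured so far, chloro in place of hydrogen on an aromatic carbon, gave a 3.7-fold lower number from compound 1 to compound 2 (0.57 log units; beyond the scatter). Compound 3 carries a methyl instead of the chloro, but no number was reported for it, so it cannot be placed among the others.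

Compound 4, `COc1cc2c(Oc3ccc(NC(=O)c4cn(-c5c(C)cccc5C)nn4)cc3F)ccnc2cc1OCCCN1CCCC1`, differs from compound 3 by methyl in place of hydrogen on an aromatic carbon. Going by the values given here, no measured step involves a methyl at all, and none adds a second group to a ring already carrying one, so the step from compound 3 to compound 4 is not covered by the measurements. The closest guide is that a single small group on this ring lowered the number in this assay.

Compound 4 is therefore expected to give roughly 90 nM in this assay, with a range from 30 nM to 300 nM, because compound 2 gives 70 nM and compound 4 likewise carries small groups on that ring.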

Compound 4, half-maximal inhibitory concentration: 3490 nM
For compound 4 the middle estimate is 39-fold (1.59 log units) below the measured one; the measured number lies above the stated range.
By their numbers in this assay, from the lowest: compound 2; then compound 1; then compound 4.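

In this assay the outer aromatic ring can push the number up as well as down: 2,6-dimethylphenyl gives a 50-fold higher number from compound 2 to compound 4 (1.70 log units; beyond the scatter) and, against the plain phenyl, a 13-fold higher number from compound 1 to compound 4 (1.13 log units; beyond the scatter) on the same core. The earlier step of a 3.7-fold lower number from compound 1 to compound 2 (0.57 log units; beyond the scatter) pointed only downward, so compound 4 shows that a small group on this ring does not always lower the number, and that two methyl groups can leave a compound weaker than one with no group there at all. Compound 3 has no number, so its step to compound 4 cannot be read, and the effect of the second methyl cannot be separated from that of the first.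

Nothing shown accounts for the rise. Still open, going by these compounds, is how a methoxy, an amine or a carboxylic acid on this ring would read, and whether a 2,6-dichlorophenyl would follow compound 2 or compound 4.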